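The source may report more compounds than this note shows. Statements on the series, on what has been measured and on what is new or still open speak of the compounds shown alone.

Working notes on the series around compound 1 `COc1ccc(/C=C/C(=O)c2ccc(NC(=S)Nc3ccc(Cl)cc3)cc2)cc1`. Within the data shown here, in a functional assay on the whole organism (Abdomen, strain Swiss) with Mus musculus as the target, with a stated time of 30 min (on this read-out higher numbers stand for an effect only at larger amounts of compound and lower numbers for an effect already at smaller amounts), compound 1 gives 10.4 umol/kg, the highest of the three numbers measured so far. Compound 2 `O=C(Nc1ccc(Cl)cc1)Nc1ccc(C(=O)/C=C/c2ccccc2)cc1` gives 7.25 umol/kg in this assay, a number within the scatter of that of compound 1; the two differ elsewhere in the structure, and no more can be said of that pair than what these two values show. Among the measured compounds shown here, compound 3 `O=C(/C=C/c1ccccc1)c1ccc(NC(=S)Nc2ccc(Cl)cc2)cc1` gives 3.03 umol/kg in this assay, and the step of a 3.4-fold lower number from compound 1 to compound 3 (0.54 log units; beyond the scatter) is the only change recorded so far at the position now in question.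

The next compound, compound 4 `Cc1ccc(/C=C/C(=O)c2ccc(NC(=S)Nc3ccc(Cl)cc3)cc2)cc1`, differs from compound 1 in one place: methyl in place of methoxy on an aromatic carbon. For the measured compounds named here, the single measured step that bears on this position is a 3.4-fold lower number from compound 1 to compound 3 (0.54 log units; beyond the scatter), in which hydrogen took the place of methoxy; the present change instead leaves a methyl there. Going by the values given here, with only this one step to draw on, a lower number than for compound 1 in this assay is expected, but of smaller size than the step to compound 3, and possibly no more than the scatter. Compound 4 is therefore estimated to give 6 umol/kg in this assay, within the range 3 umol/kg to 12 umol/kg, which would be a step of a 1.7-fold lower number from compound 1 to compound 4 (0.24 log units; within the scatter).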

Compound 4, dose for 50% inhibition: 13.1 umol/kg
Compound 4: the middle estimate sits 2.2-fold (0.34 log units) below what was measured; measured number outside the range, above it.
By their numbers in this assay, from the lowest: compound 3; then compounds 2, 1 and 4 (each within the scatter of the next).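

In this assay, the change from 4-methoxyphenyl to 4-methylphenyl gives a 1.3-fold higher number from compound 1 to compound 4 (0.10 log units; within the scatter), so the two groups cannot be told apart at this place on the ring. The earlier step from methoxy to hydrogen could have reflected something particular to methoxy, but the methyl group, which has no oxygen and counts no hydrogen-bond acceptor, also stands clearly apart from hydrogen, with a 4.3-fold higher number from compound 3 to compound 4 (0.64 log units; beyond the scatter); among these three compounds, the hydrogen compound alone has the lower number, and the oxygen of methoxy is not needed for the higher one. Nothing measured on these compounds beyond this read-out bears on why the number changes at this position.

Only hydrogen, methyl and methoxy are shown at this place, so it remains open whether the higher number holds for a chlorine atom, a hydroxyl group, an amine or a longer chain such as ethoxy. As far as these compounds go, it is also open whether methyl or methoxy at this place would have the same effect on the urea of compound 2, which carries hydrogen there.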